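This account rests on a few compounds, and the source may have more. Where it says the series, first, only, none or still open, it means among the compounds named here.

In an assay on CHO-K1 cells for displacement of a labelled ligand from melanin-concentrating hormone receptor 1 (Homo sapiens), read by scintillation proximity assay, with a stated time of 2 h (on this read-out higher numbers stand for weaker inhibition and lower numbers for stronger inhibition), compound 1, with the structure `Cc1nc(NCCNS(C)(=O)=O)nc2ccc(NC(=O)/C=C/c3ccc(OC(F)(F)F)cc3)cc12`, gives 169 nM. That is the lowest of the two numbers measured here. The other compound, compound 2, has the structure `C/C(=C\C(=O)Nc1ccc2nc(N3CCC(O)CC3)nc(C)c2c1)c1ccc(Cl)cc1` and gives 670 nM in this assay, a higher number that lies beyond the usual scatter of repeated measurements. Among the measured compounds shown here, compound 2 differs from compound 1 in more than one place, so no single structural step between measured compounds can be read from these two values.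

The next compound, compound 3, has the structure `Cc1nc(N2CCC(N3CCCC3=O)CC2)nc2ccc(NC(=O)/C=C/c3ccc(OC(F)(F)F)cc3)cc12`. It differs from compound 1 in one place: 4-(2-oxopyrrolidin-1-yl)piperidin-1-yl in place of (2-(methanesulfonamido)ethyl)amino on an aromatic carbon.

For the measured compounds named here, since no measured pair shows what this kind of change does, the expectation rests on the spread of the two numbers at hand. A modest weakening is expected, so that the step of a 1.8-fold higher number from compound 1 to compound 3 (0.25 log units; within the scatter) should be small and may well stay within the scatter. Compound 3 is therefore estimated at 300 nM in this assay, with a likely range from 100 nM to 900 nM.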

Compound 3, half-maximal inhibitory concentration: 11 nM
For compound 3 the middle estimate is 27-fold (1.44 log units) above the measured one, outside the stated range (below it).
By their numbers in this assay, from the lowest: compound 3; then compound 1; then compound 2.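

In this assay, the aromatic carbon between two ring nitrogen atoms proves highly sensitive to the group it carries: with the rest of the molecule unchanged, replacing (2-(methanesulfonamido)ethyl)amino with 4-(2-oxopyrrolidin-1-yl)piperidin-1-yl gives a 15-fold lower number from compound 1 to compound 3 (1.19 log units; beyond the scatter), a large step beyond the scatter. Among the compounds shown here, this is the first change here that can be read in one place, and it shows that the open chain, with no ring and 2 hydrogen-bond donors, is not needed for a low number, as a group with two non-aromatic rings and 0 hydrogen-bond donors does better at this position. Nothing available here shows which of the many differences between the two groups accounts for the step.

For the compounds shown here, the single swap changes the ring content, the sulfur, the donors and the size of the group all at once, so the contribution of each part stays open. A plain piperidin-1-yl, or a piperidine carrying an amine or a carboxylic acid where the 2-oxopyrrolidin-1-yl ring sits, would show whether the piperidine alone goes with the lower number or whether the group on it matters too.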